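Swapping the Amine Substituent: From Compound 3 to Compound 4

This account rests on a few compounds, and the source may have more. Where it says the series, first, only, none or still open, it means among the compounds named here.

Compound 1 `O=C(CCc1ccc(C(F)(F)F)cc1)Nc1ccc2nc(N3CCC3)ccc2c1` gives 56 nM in a functional assay on HEK293 cells for activation of melanin-concentrating hormone receptor 1 (Rattus norvegicus), read by inositol phosphate accumulation; a higher number here means that more compound is needed for the effect, a lower number that less compound is needed.
Compound 2 `CC1CCCN1c1ccc2cc(NC(=O)CCc3ccc(C(F)(F)F)cc3)ccc2n1` gives 270 nM in this assay.
Compound 3 `CN(c1ccc2cc(NC(=O)CCc3ccc(C(F)(F)F)cc3)ccc2n1)C1CCCC1` gives 350 nM in this assay.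

In this assay, compound 3 has the highest of the three numbers; compound 2 stands within the scatter of it, while compound 1 lies clearly lower. The change considered is 3-phenylpyrrolidin-1-yl in place of cyclopentyl(methyl)amino on an aromatic carbon, which gives compound 4 `O=C(CCc1ccc(C(F)(F)F)cc1)Nc1ccc2nc(N3CCC(c4ccccc4)C3)ccc2c1`. For the measured compounds named here, two measured steps bear on it: a 4.8-fold higher number from compound 1 to compound 2 (0.68 log units; beyond the scatter) and a 6.3-fold higher number from compound 1 to compound 3 (0.80 log units; beyond the scatter), each a modest rise when azetidin-1-yl was replaced by a bigger amine. Meanwhile a 1.3-fold higher number from compound 2 to compound 3 (0.11 log units; within the scatter) shows that exchanging one such amine for another changed nothing beyond the scatter. Going by the values given here, no measured step covers a phenyl on the ring, so the expected step is small and uncertain in direction: a 1.2-fold lower number from compound 3 to compound 4 (0.07 log units; within the scatter). Compound 4 is estimated at 300 nM, with a range from 60 nM to 1500 nM.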

Compound 4, half-maximal effective concentration: 1770 nM
For compound 4 the middle estimate is 5.9-fold (0.77 log units) below the measured one; measured number above the stated range.
By their numbers in this assay, from the lowest: compound 1; then compounds 2 and 3 (each within the scatter of the next); then compound 4.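

In this assay, this position does separate larger amines: 3-phenylpyrrolidin-1-yl stands clearly apart from cyclopentyl(methyl)amino (a 5.1-fold higher number from compound 3 to compound 4 (0.70 log units; beyond the scatter)) and from 2-methylpyrrolidin-1-yl (a 6.6-fold higher number from compound 2 to compound 4 (0.82 log units; beyond the scatter)), two groups that had stayed within the scatter of each other. Against azetidin-1-yl, the step is now large (a 32-fold higher number from compound 1 to compound 4 (1.50 log units; beyond the scatter)). No measurement here explains this rise.

Going by these compounds, it remains open whether the rise belongs to the phenyl or to the ring that carries it. A plain pyrrolidin-1-yl at this position would separate the two.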